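The source may report more compounds than this note shows. Statements on the series, on what has been measured and on what is new or still open speak of the compounds shown alone.

Series notes, measured in a functional assay on HCT-116 cells (Homo sapiens) for inhibition, read by MTT assay, with a stated time of 72 h; on this read-out lower numbers stand for stronger inhibition of growth and higher numbers for weaker inhibition of growth:
- compound 1 `O[C@H](COCCOC[C@@H](O)Cc1cn(Cc2ccc3ccccc3c2)nn1)Cc1ccc(-c2ccccc2)cc1`: 8600 nM
- compound 2 `O[C@H](COCCOC[C@@H](O)Cc1cn(Cc2ccc(Oc3ccccc3)cc2)nn1)Cc1ccc(-c2ccccc2)cc1`: 3400 nM
- compound 3 `O[C@H](COCCOC[C@@H](O)Cc1cn(-c2cncnc2)nn1)Cc1ccc(-c2ccccc2)cc1`: > 100000 nM

Only compound 1 and compound 2 give actual numbers. Compound 1 has the higher of the two at 8600 nM, while compound 2 has the lower at 3400 nM. Compound 3 gives > 100000 nM, which is a limit of the assay and not a number.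

The next compound is compound 4 `O[C@H](COCCOC[C@@H](O)Cc1cn(Cc2ccc(C(F)(F)F)cc2)nn1)Cc1ccc(-c2ccccc2)cc1`. Compared with compound 1, it has 4-(trifluoromethyl)phenyl in place of naphthalen-2-yl on a saturated chain carbon bound to an aromatic nitrogen.

Going by the values given here, the only measured step is an at least 11-fold higher number from compound 1 to compound 3 (1.06 log units; beyond the scatter). This large step, beyond the scatter, bears only loosely on the present change: it puts pyrimidin-5-yl in place of (naphthalen-2-yl)methyl on an aromatic nitrogen, whereas compound 4 keeps the saturated chain carbon found in compound 1. Compound 2 also keeps that carbon and gives 3400 nM, so a drop to the level of compound 3 is not expected in this assay.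

No step beyond the scatter is expected, and the estimated step is a 1.0-fold higher number from compound 1 to compound 4 (0.02 log units; within the scatter). The expected value for compound 4 is 9000 nM. The estimated range for compound 4 runs from 3500 nM to 30000 nM.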

Compound 4, concentration for 50% growth inhibition: 2500 nM
Estimate against measurement, compound 4: 3.6-fold (0.56 log units) above; measured number below the stated range.
By their numbers in this assay, from the lowest: compounds 4 and 2 (each within the scatter of the next); then compound 1. At a limit, above all of these: compound 3.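

In this assay, the step of a 3.4-fold lower number from compound 1 to compound 4 (0.54 log units; beyond the scatter) shows that this position does not need the two aromatic rings of naphthalen-2-yl: a benzyl group with one carbon ring and a trifluoromethyl group does better here than (naphthalen-2-yl)methyl. The step of a 1.4-fold lower number from compound 2 to compound 4 (0.13 log units; within the scatter) lies within the scatter, so trifluoromethyl and phenoxy on an aromatic carbon cannot be ranked, and the larger phenoxy group brings no measurable advantage over trifluoromethyl. The step of an at least 40-fold lower number from compound 3 to compound 4 (1.60 log units; beyond the scatter) shows that 4-(trifluoromethyl)benzyl gives measurable growth inhibition where pyrimidin-5-yl does not, but its size remains a bound because compound 3 stands at a limit of the assay: the limit of > 100000 nM in this assay, at which 1 of the 4 values shown sits.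

As far as these compounds go, it remains open whether the loss at compound 3 follows from the missing saturated chain carbon or from the pyrimidin-5-yl ring itself, as that step alters both at once. Also open, from the compounds shown here alone, is how an unsubstituted benzyl group, a carboxylic acid or an amine in place of trifluoromethyl, or a longer chain to the aromatic nitrogen would stand in this assay.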